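Removing the dimethylamino group from the aryloxy side of compound 2

The compounds below may be only part of what the source reports. "The series", "measured", "known", "first", "only" and "open" are said of these compounds alone.

Among the compounds with values here, compound 2 `COc1ccc(F)cc1CNCCCNc1ccnc2cc(Oc3cccc(N(C)C)c3)ccc12` has the lowest of the two numbers so far: in an ADME assay on HepG2 cells (Homo sapiens) for cytotoxicity, read by luminescence, CellTiter-Glo and ATP content, with a stated time of 72 h (on this read-out lower numbers stand for an effect already at smaller amounts and higher numbers for an effect only at larger amounts of compound), compound 2 gives 3300 nM, whereas compound 1 `CCC(CC)c1ccc2c(NCCCNCc3cc(F)ccc3OC)ccnc2c1` gives 7860 nM. Within the data shown here, the single measured step, a 2.4-fold lower number from compound 1 to compound 2 (0.38 log units; beyond the scatter), exchanges a whole substituent and does not isolate the dimethylamino group. Compound 3 `COc1ccc(F)cc1CNCCCNc1ccnc2cc(Oc3ccccc3)ccc12` differs from compound 2 by hydrogen in place of dimethylamino on an aromatic carbon. Among the measured compounds shown here, no measured step bears directly on this change, so in this assay no step beyond the scatter is expected, the number for compound 3 drifting at most slightly higher. Compound 3 is estimated at 4500 nM, range 2000 nM to 10000 nM, a step of a 1.4-fold higher number from compound 2 to compound 3 (0.13 log units; within the scatter).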

Compound 3, half-maximal effective concentration in the HepG2 assay: 1500 nM
Compound 3: middle estimate off by 3.0-fold (0.48 log units), on the high side, outside the stated range (below it).
By their numbers in the HepG2 assay, from the lowest: compound 3; then compound 2; then compound 1.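

In the HepG2 assay, this position now has its own read: the step of a 2.2-fold lower number from compound 2 to compound 3 (0.34 log units; beyond the scatter) runs opposite to the small upward drift expected, and phenoxy in place of pentan-3-yl gives a 5.2-fold lower number from compound 1 to compound 3 (0.72 log units; beyond the scatter) as the step across the substituent exchange. In a physicochemical assay for solubility, with a stated time of 18 h, at pH 7.4 (on this read-out lower numbers stand for lower solubility and higher numbers for higher solubility), compound 2 gives 14500 nM and compound 3 gives 14500 nM as the same printed value, so the two read-outs part on this exchange. Nothing available accounts for the lower number on losing dimethylamino.

Still open, as far as these compounds go, is how methoxy, a carboxylic acid or a longer aminoalkyl chain on the same aromatic carbon would read against hydrogen. From the compounds shown here alone, whether the solubility read-out stays flat with such groups is equally open.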